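The source may report more compounds than this note shows. Statements on the series, on what has been measured and on what is new or still open speak of the compounds shown alone.

Measured in a toxicity assay on THP-1 cells (Homo sapiens) for inhibition; on this read-out lower numbers stand for higher toxicity in this test and higher numbers for lower toxicity in this test:
Compound 1 `Cn1c(-c2ccccc2F)cnc1NC(=O)c1ccc(F)cc1`: > 100000 nM
Compound 2 `Cn1cc(-c2ccccc2)nc1NC(=O)c1ccc(F)cc1`: > 50000 nM

Neither compound gives a number in this assay. Compound 1 stands only at a limit, > 100000 nM, and no toxicity value can be read from it. Compound 2 likewise stands only at a limit, > 50000 nM. These two limits are all that is known, so neither compound can be placed above the other.

The next compound is compound 3 `Cn1c(-c2ccc(C#N)cc2)cnc1NC(=O)c1ccc(F)cc1`. Compared with compound 1, it carries 4-cyanophenyl in place of 2-fluorophenyl on an aromatic carbon, while the rest of the structure stays the same: 4-cyanophenyl in place of 2-fluorophenyl on an aromatic carbon.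

Going by the values given here, no measured step between two compounds is available to size such a change. With only limits to go on, the expectation is that compound 3 also shows low toxicity in this assay, quite possibly as another limit rather than a number. The expected change is an at least 1.4-fold lower number from compound 1 to compound 3 (0.15 log units; that floor lies within the scatter), and it is not expected to go beyond the scatter. For compound 3 the estimated value is 70000 nM, with an expected range of 25000 nM to 150000 nM.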

Compound 3, half-maximal cytotoxic concentration: > 50000 nM
Compound 3 ended at the assay's limit; the forecaster's own chance of this, stated with the estimate: 75%; the middle value lies beyond the limit too.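

Going by these compounds alone, compound 1 and compound 3 both stand only at limits in this assay, so no step between them can be read for 4-cyanophenyl in place of 2-fluorophenyl. The compounds shown leave open whether any of them would give an actual number in this assay, and how such numbers would compare.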